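A few compounds are considered here, and "the series" means these few. Any claim that something is new, unique, unknown or untested is made for them only; others in the source may bear on it.

Compound 3 `COc1ccc([C@H]2[C@@H](c3ccccc3)N[C@@]3(C(=O)Nc4ccccc43)[C@]23CCc2c([nH]c4ccc(C)cc24)C3=O)cc1` was tested in a functional assay on MCF7 cells (Homo sapiens) for antiproliferative activity, read by MTT assay, with a stated time of 48 h (on this read-out lower numbers stand for stronger inhibition and higher numbers for weaker inhibition), where it gives 18000 nM. Compound 1 `O=C1Nc2ccccc2[C@]12N[C@H](c1ccccc1)[C@H](c1ccccc1)[C@@]21CCc2c([nH]c3ccccc23)C1=O` gives 15000 nM in this assay, and compound 2 `Cc1ccc2[nH]c3c(c2c1)CC[C@]1(C3=O)[C@@H](c2cccs2)[C@@H](c2ccccc2)N[C@@]12C(=O)Nc1ccccc12` gives 14000 nM; the gaps from compound 3 to each of these lie within the scatter, so the three numbers cannot be told apart. Among the measured compounds shown here, the only one-place step among them, a 1.3-fold higher number from compound 2 to compound 3 (0.11 log units; within the scatter), concerns a substituent on a saturated ring carbon and also lies within the scatter. Compound 4 `COc1ccc([C@H]2[C@@H](c3ccccc3)N[C@@]3(C(=O)Nc4ccccc43)[C@]23CCc2c([nH]c4ccccc24)C3=O)cc1` differs from compound 3 by hydrogen in place of methyl on an aromatic carbon: one carbon atom leaves, no ring is changed, and the site is on a six-membered aromatic ring of carbon only, part of a fused or bridged system of six rings. For the measured compounds named here, no measured step removes this methyl on its own; compound 1 lacks it but differs elsewhere as well, and its value is indistinguishable from that of compound 3. The expected step is therefore a 1.1-fold lower number from compound 3 to compound 4 (0.02 log units; within the scatter), nothing beyond the scatter. Compound 4 is expected to give about 17000 nM, within 8000 nM to 36000 nM.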

Compound 4, half-maximal inhibitory concentration: 17000 nM
Beside the measured number, compound 4's estimate shows no gap at the digits printed; low and high end bracket the measured number.
By their numbers in this assay, from the lowest: compounds 2, 1, 4 and 3 (each within the scatter of the next).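

Taken alone for the first time, the loss of the methyl from this six-membered aromatic ring of carbon only gives a 1.1-fold lower number from compound 3 to compound 4 (0.02 log units; within the scatter) in this assay and so makes no readable difference at this position. The second new step, a 1.1-fold higher number from compound 1 to compound 4 (0.05 log units; within the scatter) for methoxy in place of hydrogen on an aromatic carbon, is just as small, so neither change separates these compounds. Nothing available bears on why these numbers stay so close.

The methyl and hydrogen compounds shown here lie within the scatter of each other, so they do not show whether this position can affect the read-out at all. From the compounds shown here alone, what a carboxylic acid, an amine or a longer chain such as propyl would do at this aromatic carbon remains open.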